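This account rests on a few compounds, and the source may have more. Where it says the series, first, only, none or still open, it means among the compounds named here.

Compound 2 `Cc1c(C(=O)NCCCN2CCN(C)CC2)c(-c2cccc(N3CCN(c4ccc(NS(=O)(=O)c5cccc(OC(F)(F)F)c5)cc4)CC3)c2)c(-c2ccc(Cl)cc2)n1C` carries an amide-linked chain on the shared core and a 3-(trifluoromethoxy)phenyl sulfonamide at the far end. In an assay for inhibition of Apoptosis regulator Bcl-2 (Homo sapiens), read by fluorescence polarization, with a stated time of 2 h (on this read-out lower numbers stand for stronger inhibition and higher numbers for weaker inhibition), compound 2 gives 763 nM, the highest number of the three measured here. Compound 1 `Cc1c(C(=O)O)c(-c2cccc(N3CCN(c4ccc(NS(=O)(=O)c5ccc(N[C@H](CCN6CCC(O)CC6)CSc6ccccc6)c(S(=O)(=O)C(F)(F)F)c5)cc4)CC3)c2)c(-c2ccc(Cl)cc2)n1C`, which bears an acid on the core and a much larger substituted sulfonamide, gives 10.2 nM in this assay, and compound 3 `Cc1c(C(=O)O)c(-c2cccc(N3CCN(c4ccc(NS(=O)(=O)c5ccc(N[C@H](CCN6CCC(C)(O)CC6)CSc6ccccc6)c(S(=O)(=O)C(F)(F)F)c5)cc4)CC3)c2)c(-c2ccc(Cl)cc2)n1C` gives 18.6 nM; both of those numbers lie far below that of compound 2, but each differs from compound 2 in more than one place, so no single step can be read from them.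

Compound 4 `Cc1c(C(=O)NCCCN2CCN(C)CC2)c(-c2cccc(N3CCN(c4ccc(NS(=O)(=O)c5cccc(S(C)(=O)=O)c5)cc4)CC3)c2)c(-c2ccc(Cl)cc2)n1C` is the next compound to be measured. The change from compound 2 is methylsulfonyl in place of trifluoromethoxy on an aromatic carbon; one small group leaves and another of similar size enters on an aromatic carbon of a six-membered aromatic ring of carbon only, meta to a large group. Among the compounds with values here, no measured pair shows this exact exchange, so its effect is unknown. The two groups are both small, neutral and without a ring, so a step of modest size is expected, if any beyond the scatter, and with no clear direction. Compound 4 is therefore estimated at 900 nM in this assay, within a range of 300 nM to 3000 nM, an expected step of a 1.2-fold higher number from compound 2 to compound 4 (0.07 log units; within the scatter).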

Compound 4, half-maximal inhibitory concentration: 2540 nM
The estimate for compound 4 lay 2.8-fold (0.45 log units) below the measured number; low and high end bracket the measured number.
By their numbers in this assay, from the lowest: compounds 1 and 3 (each within the scatter of the next); then compound 2; then compound 4.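

Within the data shown here, the exchange of trifluoromethoxy for methylsulfonyl gives the first single-place step in this set: in this assay it produces a 3.3-fold higher number from compound 2 to compound 4 (0.52 log units; beyond the scatter), modest but beyond the scatter, and the higher number stands for weaker inhibition. The earlier compounds shown here could not show this, as compounds 1 and 3 each differ from compound 2 in more than one place, so it is only now clear that this aromatic carbon, meta to a large group, does not tolerate every small group equally, even when both groups are neutral, have no ring and differ by a single heavy atom. Nothing measured here accounts for the shift in the number, so the difference in hydrogen-bond acceptor count can be noted but not tied to the result.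

The compounds shown leave open how a nitrile, a chlorine atom or a plain hydrogen would read on this same aromatic carbon, and so whether trifluoromethoxy or methylsulfonyl lies nearer the usual outcome there. They also leave open whether this exchange would move the number in the same direction with a carboxylic acid on the shared core in place of the amide-linked chain.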